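A few compounds are considered here, and "the series" means these few. Any claim that something is new, unique, unknown or untested is made for them only; others in the source may bear on it.

Of the compounds shown here, two sharing one core have been measured for how much of them cells tolerate. For the measured compounds named here, compound 1 `O=C(Nc1cccc(C(F)(F)F)c1)c1c(NO)cc(-c2ccccc2)oc1=O` is the first; in an ADME assay on Huh-7 cells (Homo sapiens) for cytotoxicity, with a stated time of 3 days (a higher number here means that more compound is tolerated, a lower number that less compound is tolerated), compound 1 gives 19000 nM. Compound 2 `O=C(Nc1ccccc1)c1c(NO)cc(-c2cccs2)oc1=O` is the second. In this assay compound 2 gives > 20000 nM, and this is a limit of the assay rather than a number. Compound 2 thus stands at the limit of > 20000 nM in this assay, at which 1 of the 2 values shown sits. Compound 3 `Cc1ccccc1NC(=O)c1c(NO)cc(-c2cccs2)oc1=O` differs from compound 2 in a single place: methyl in place of hydrogen on an aromatic carbon. Going by the values given here, no pair of measured compounds shows the effect of such a change, so there is no measured step to lean on, and no shift beyond the ordinary scatter of this assay is expected in either direction. The step from compound 2 to compound 3 is estimated at a number no higher from compound 2 to compound 3 (the limit leaves the size open). Compound 3 is expected to give about 20000 nM, within a range from 8000 nM to 40000 nM, and the assay may again report only a limit.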

Compound 3, half-maximal cytotoxic concentration: > 20000 nM
Compound 3: a limit, no number; the forecaster's own chance of this, stated with the estimate: 55%; the middle value sits exactly at the limit.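

For the compounds shown here, compound 2 and compound 3 each give only a limit of the assay in this assay, so no step between them can be read: the limit of > 20000 nM in this assay, at which 2 of the 3 values shown sit. On these data alone, whether methyl in place of hydrogen on this aromatic carbon changes how much compound the cells tolerate stays open.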